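Nitro to Methyl on the Sulfonyl Aryl Ring

The compounds below may be only part of what the source reports. "The series", "measured", "known", "first", "only" and "open" are said of these compounds alone.

Compound 1 `COc1cc2nc(N3CCN(C(=O)OCc4ccccc4)CC3)nc(N)c2cc1OC` gives 63000 nM in a functional assay on PC-3 cells (Homo sapiens) for inhibition; on this read-out lower numbers stand for stronger inhibition and higher numbers for weaker inhibition. Compound 2 `COc1cc2nc(N3CCN(S(=O)(=O)c4ccc([N+](=O)[O-])cc4)CC3)nc(N)c2cc1OC` gives 36000 nM in this assay.

Compound 2 has the lower of the two numbers, but its gap to compound 1 lies within the scatter, so the two cannot be ranked. Compound 3 `COc1cc2nc(N3CCN(S(=O)(=O)c4ccc(C)cc4)CC3)nc(N)c2cc1OC` differs from compound 2 by methyl in place of nitro on an aromatic carbon. Among the compounds with values here, no measured pair here shows such a change, and the two known values sit close together at weak inhibition, so the expected step in this assay is small, none beyond the scatter. The expected step is a 1.3-fold higher number from compound 2 to compound 3 (0.10 log units; within the scatter). Compound 3 is estimated at 45000 nM, ranging from 15000 nM to 130000 nM.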

Compound 3, half-maximal inhibitory concentration: 30000 nM
The estimate for compound 3 lay 1.5-fold (0.18 log units) above the measured number, and the stated range covers the measured number.
By their numbers in this assay, from the lowest: compounds 3, 2 and 1 (each within the scatter of the next, the first and the last beyond it).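

Methyl in place of nitro on this aromatic carbon, para to a large group, gives a 1.2-fold lower number from compound 2 to compound 3 (0.08 log units; within the scatter) in this assay and so does not separate the two groups at this position. Within the data shown here, compound 3 also provides the only step here beyond the scatter, though a modest one: (4-methylphenyl)sulfonyl in place of benzyloxycarbonyl on the ring amine nitrogen gives a 2.1-fold lower number from compound 1 to compound 3 (0.32 log units; beyond the scatter) in this assay and all three values remain weak. No available evidence accounts for either step.

From the compounds shown here alone, whether an amine or a carboxylic acid on this aromatic carbon would give a different number remains open.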